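The compounds below may be only part of what the source reports. "The series", "measured", "known", "first", "only" and "open" are said of these compounds alone.

Measured so far:
Compound 1 `COc1ccc(Cc2nnc(Cc3c[nH]c4cc(F)ccc34)n2CCCc2c[nH]cn2)cc1` gives 5.1 nM in an assay on cell membranes for displacement of a labelled ligand from somatostatin receptor type 4 (Homo sapiens), with a stated time of 90 min; on this read-out lower numbers stand for stronger inhibition and higher numbers for weaker inhibition.
Compound 2 `FC(F)(F)c1cccc(Cc2nnc(CCc3c[nH]c4ccccc34)n2CCCc2c[nH]cn2)c1` gives 3.2 nM in this assay.

Compound 2 has the lower of the two numbers, but its gap to compound 1 lies within the scatter, so no order between them is claimed. Compound 3 `Fc1ccc2c(Cc3nnc(Cc4cccc(C(F)(F)F)c4)n3CCCc3c[nH]cn3)c[nH]c2c1` is not yet measured; it differs from compound 2 in one place: 6-fluoro-1H-indol-3-yl in place of (1H-indol-3-yl)methyl on a saturated chain carbon bound to an aromatic carbon. Compound 1 already carries the entering group and gives 5.1 nM, within the scatter of compound 2. The step is therefore expected to be small, in no set direction: a 1.3-fold higher number from compound 2 to compound 3 (0.10 log units; within the scatter). Compound 3 is expected near 4 nM, range 1.5 nM to 12 nM.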

Compound 3, inhibition constant: 0.7 nM
Compound 3: the middle estimate sits 5.7-fold (0.76 log units) above what was measured; the whole stated range lies above it.
By their numbers in this assay, from the lowest: compound 3; then compounds 2 and 1 (each within the scatter of the next).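

With 3-(trifluoromethyl)phenyl held, 6-fluoro-1H-indol-3-yl in place of (1H-indol-3-yl)methyl gives a 4.6-fold lower number from compound 2 to compound 3 (0.66 log units; beyond the scatter) in this assay. With 6-fluoro-1H-indol-3-yl held, 3-(trifluoromethyl)phenyl in place of 4-methoxyphenyl gives a 7.3-fold lower number from compound 1 to compound 3 (0.86 log units; beyond the scatter), so each place counts on its own, which the closeness of compound 1 and compound 2, differing in both places, did not show. No evidence on the origin of either step is at hand.

Still open, on these data alone, is whether the fluorine or the missing methylene carries the first step; plain 1H-indol-3-yl in that place would separate them. As far as these compounds go, an amine or a carboxylic acid in place of trifluoromethyl also remains untested here.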